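Swapping an aromatic ring for a saturated one

The source may hold more compounds than are shown below. What is called first, only, known or untested is meant among the compounds shown, and "the series" means these compounds.

Measured compounds and their results in an ADME assay on HepG2 cells (Homo sapiens) for cytotoxicity, read by luminescence, CellTiter-Glo and ATP content, with a stated time of 72 h; on this read-out higher numbers stand for an effect only at larger amounts of compound and lower numbers for an effect already at smaller amounts:
- compound 1, `Cc1cc(C)cc(Cc2ccc3c(NCCCNCc4ccco4)ccnc3c2)c1`: 6270 nM
- compound 2, `COc1cccc(CNCCCNc2ccnc3cc(Cc4cc(C)cc(C)c4)ccc23)c1O`: 2680 nM
- compound 3, `CCC(CC)c1ccc2c(NCCCNCc3cc(F)ccc3OC)ccnc2c1`: 7860 nM

Compound 1 gives the second highest of these three numbers; compound 3 sits within the scatter of it, while compound 2 lies a 2.3-fold lower number from compound 1 to compound 2 (0.37 log units; beyond the scatter). Compound 4, `c1coc(CNCCCNc2ccnc3cc(CC4CCCCC4)ccc23)c1`, differs from compound 1 in one place: cyclohexyl in place of 3,5-dimethylphenyl on a saturated chain carbon bound to an aromatic carbon. Within the data shown here, the only measured step, from compound 1 to compound 2, alters the other end of the molecule and so says nothing direct about this change; no measured pair separates the two groups in question. Without guidance, compound 4 is expected to stay close to compound 1, giving a 1.1-fold lower number from compound 1 to compound 4 (0.06 log units; within the scatter) in this assay. Compound 4 is therefore estimated at 5500 nM, within 2500 nM to 12000 nM.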

Compound 4, half-maximal effective concentration: 1700 nM
Estimate against measurement, compound 4: 3.2-fold (0.51 log units) above, and the stated range ends above it.
By their numbers in this assay, from the lowest: compounds 4 and 2 (each within the scatter of the next); then compounds 1 and 3 (each within the scatter of the next).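

In this assay, this place on the saturated chain carbon bound to an aromatic carbon proves to matter: cyclohexyl in place of 3,5-dimethylphenyl gives a 3.7-fold lower number from compound 1 to compound 4 (0.57 log units; beyond the scatter). Among these compounds, the earlier step changed only the other end of the molecule, so this is the first sign that this end can also shift the number, here towards an effect at smaller amounts. Nothing available gives a reason for the shift. Going by these compounds, whether the step follows from losing the aromatic ring or losing the methyl groups stays open. A plain phenyl at this place would help separate the two.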